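From 2-fluorophenyl to 4-cyanophenyl at the assay limit

The source may hold more compounds than are shown below. What is called first, only, known or untested is meant among the compounds shown, and "the series" means these compounds.

Compound 3 `O=C(/C=C/c1cc(C(=O)c2ccccc2F)c[nH]1)CC(=O)C(=O)O` has no exact potency so far in an ADME assay on HeLa cells (Homo sapiens) for inhibition, read by MTT assay, with a stated time of 48 h; a lower number here means a stronger inhibitor, a higher number a weaker inhibitor. Compound 3 gives > 40000 nM, which is a limit of the assay and not a number. Compound 2 `CCOC(=O)C(=O)CC(=O)/C=C/c1cc(C(=O)c2ccccc2F)c[nH]1` carries ethyl on an oxygen next to a carbonyl group, where compound 3 carries hydrogen. Compound 2 gives > 40000 nM, which is also a limit. Compound 1 `O=C(/C=C/c1cn(CC(=O)N2CCOCC2)c2ccccc12)CC(=O)C(=O)O` has a different core. Compound 1 gives > 40000 nM, again a limit. The whole record so far is the limit of > 40000 nM in this assay, at which 3 of the 3 values shown sit.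

Compound 4 `N#Cc1ccc(C(=O)c2c[nH]c(/C=C/C(=O)CC(=O)C(=O)O)c2)cc1` differs from compound 3 in one place, with 4-cyanophenyl in place of 2-fluorophenyl on a carbonyl carbon.

Going by the values given here, the only measured step that links two close relatives is a step that the two limits leave unreadable from compound 2 to compound 3. It changes a different part of the molecule and has no readable size, so it offers nothing to carry over. Among the compounds with values here, no compound here has an exact value in this assay, and so no direction can be predicted, and no step beyond the scatter is expected. The expected step is a step that the limit leaves unreadable from compound 3 to compound 4. Compound 4 is estimated to give about 50000 nM, with an expected range of 20000 nM to 120000 nM, and the assay will probably report only a limit again.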

Compound 4, half-maximal inhibitory concentration: > 40000 nM
Compound 4: only a limit was reported; the forecaster's own chance of this, stated with the estimate: 85%; the middle value lies beyond the limit too.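

In this assay compound 4 gives > 40000 nM, which is a limit of the assay and not a number. Compound 3 also sits at a limit, so the swap from 2-fluorophenyl to 4-cyanophenyl between compound 3 and compound 4 has no readable size. The compounds shown leave open how any of them ranks in potency, as the whole record is a single limit: the limit of > 40000 nM in this assay, at which 4 of the 4 values shown sit.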